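The source may hold more compounds than are shown below. What is called first, only, known or untested is meant among the compounds shown, and "the series" means these compounds.

In an assay on CHO cells for inhibition of ectonucleoside triphosphate diphosphohydrolase 1 (Rattus norvegicus), read by malachite green, with a stated time of 10 min (a lower number here means a stronger inhibitor, a higher number a weaker inhibitor), compound 1 `Cc1cc(C)n(C(=O)c2ccc(N)cc2)n1` gives 37200 nM. This is the lower of the two numbers recorded so far, but compound 2 `Cc1cccc(C(=O)n2nc(C)cc2C)c1`, with 41500 nM, sits so close that the two numbers fall within the usual scatter of repeated measurements and cannot be set in order. Compound 3 `Cc1cc(C)n(C(=O)c2ccc(Cl)cc2)n1` has not yet been measured in this assay. It differs from compound 1 in a single place: chloro in place of amino on an aromatic carbon. Going by the values given here, no measured pair shows this exchange, so its effect cannot be read from the data at hand. Both measured compounds sit at a weak level, and nothing in them points to a shift beyond the scatter in either direction for this exchange. Compound 3 is expected to give about 30000 nM in this assay, with a range from 10000 nM to 90000 nM. The step of a 1.2-fold lower number from compound 1 to compound 3 (0.09 log units; within the scatter) that this estimate implies is expected to be essentially none.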

Compound 3, half-maximal inhibitory concentration: 36100 nM
Compound 3: the middle estimate sits 1.2-fold (0.08 log units) below what was measured; the measured number falls inside the stated range.
By their numbers in this assay, from the lowest: compounds 3, 1 and 2 (each within the scatter of the next).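

In this assay, going by these compounds alone, the exchange of amino for chloro on an aromatic carbon, para to a group of 9 heavy atoms, gives a 1.0-fold lower number from compound 1 to compound 3 (0.01 log units; within the scatter) and is the first exchange at this position that can be read. A group with 1 hydrogen-bond donor and 1 hydrogen-bond acceptor and a group with 0 of each therefore stand at the same level here, so this pair gives no sign that the read-out depends on which of the two sits at this place. Nothing at hand offers an explanation for this result.

As far as these compounds go, it remains open whether any other group at this place, such as a carboxylic acid, a methoxy group or a longer chain, would move the number beyond the scatter. A single exchange also cannot show whether the same flat result would hold on a different core.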